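Adding a Methyl to the Nitrogen of Compound 2

A few compounds are considered here, and "the series" means these few. Any claim that something is new, unique, unknown or untested is made for them only; others in the source may bear on it.

In a functional assay on A549 cells (Homo sapiens) for inhibition (a lower number here means a stronger inhibitor, a higher number a weaker inhibitor), compound 1 `COc1cc(/C=C/c2ccc3[nH]ccc3c2)cc(OC)c1OC` gives 470 nM, and compound 2 `COc1cc(/C=C\c2ccc3[nH]ccc3c2)cc(OC)c1OC` gives 390 nM. All that separates these two is the fact that compounds 1 and 2 differ only in the configuration as drawn. Going by the values given here, the measured step is a 1.2-fold lower number from compound 1 to compound 2 (0.08 log units; within the scatter), so compound 2 stands level with compound 1, the only other compound measured so far.

Compound 3 `COc1cc(/C=C\c2ccc3c(ccn3C)c2)cc(OC)c1OC` keeps the double bond of compound 2 and changes one thing: methyl in place of hydrogen on an aromatic nitrogen. In words, this is methyl in place of hydrogen on an aromatic nitrogen. Among the compounds with values here, the single measured step bears on this only loosely, since it concerns the double bond and leaves that nitrogen untouched. Within the data shown here, no measured compound carries a group there, so the data give neither a size nor a direction for the change.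

The best starting point is therefore the value of compound 2, 390 nM, with no shift beyond the scatter expected in this assay. The expected change is a 1.0-fold higher number from compound 2 to compound 3 (0.01 log units; within the scatter), although a real move either way remains possible. For compound 3 the estimate is 400 nM, with an expected range from 90 nM to 1800 nM.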

Compound 3, half-maximal inhibitory concentration: 470 nM
Compound 3: the middle estimate sits 1.2-fold (0.07 log units) below what was measured, and the stated range covers the measured number.
By their numbers in this assay, from the lowest: compounds 2, 1 and 3 (each within the scatter of the next).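

Until now, every compound carried hydrogen on the aromatic nitrogen of the five-membered ring, so nothing spoke to this position. In this assay, going by these compounds alone, putting methyl in place of that hydrogen gives a 1.2-fold higher number from compound 2 to compound 3 (0.08 log units; within the scatter), the first reading of a group at this nitrogen. The two numbers stand level, so for this pair, which shares the double bond as drawn in compound 2, the hydrogen on the nitrogen is not needed to hold the number at this level, and a methyl, counted with no hydrogen-bond donors, fits there without a step beyond the scatter; nothing known about these compounds explains why the numbers stand level.

Going by these compounds, what stays open is how far this reaches, since a single small group at a single position says little about larger or different ones: a longer chain such as propyl, a benzyl group, or a chain ending in an amine or a carboxylic acid on that nitrogen could give quite different numbers. On these data alone, it is also open whether methyl at this nitrogen would read the same way on compound 1, with its double bond drawn the other way.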